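This account rests on a few compounds, and the source may have more. Where it says the series, first, only, none or still open, it means among the compounds named here.

Measured in a functional assay (QGY7701 cells, Homo sapiens) for inhibition, read by MTT assay, with a stated time of 48 h; on this read-out lower numbers stand for stronger inhibition and higher numbers for weaker inhibition:
compound 1, `COc1ccc2c(=O)c(/C=C/C(=O)Nc3ccc(Cl)cc3)coc2c1`: > 100000 nM
compound 2, `COc1ccc2c(=O)c(/C=C/C(=O)NCc3ccc(F)cc3)coc2c1`: 7960 nM
compound 3, `CCOc1ccc(NC(=O)/C=C/c2coc3cc(OC)ccc3c2=O)cc1`: > 100000 nM

The value of compound 3 is a limit of the assay, not a number. The value of compound 1 is likewise only a limit. Going by the values given here, compound 2 is the single member of the series with a measured number in this assay. Its two steps are large: an at least 12-fold lower number from compound 1 to compound 2 (1.09 log units; beyond the scatter) and an at least 12-fold higher number from compound 2 to compound 3 (1.09 log units; beyond the scatter). The step that the two limits leave unreadable from compound 1 to compound 3 stays unreadable, since both ends sit at the limit of > 100000 nM in this assay, at which 2 of the 3 values shown sit.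

Compound 4, `COc1ccc(NC(=O)/C=C/c2coc3cc(OC)ccc3c2=O)cc1`, is the next member. It differs from compound 3 by hydrogen in place of methyl on a saturated chain carbon bound to an oxygen on an aromatic ring. Among the compounds with values here, no measured step touches that position directly; the closest comparison is the ethoxy-for-chloro exchange from compound 1 to compound 3, which the two limits leave unreadable. Both compounds carrying a 4-chlorophenyl or a 4-ethoxyphenyl on the amide-type nitrogen sit at the limit, and compound 4 keeps that pattern of substitution. Compound 4 is therefore expected to remain at or near the limit, with the expected step that the limit leaves unreadable from compound 3 to compound 4 not readable. The estimate for compound 4 is 150000 nM, within 20000 nM to 1000000 nM.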

Compound 4, half-maximal inhibitory concentration: > 100000 nM
Compound 4: no number, only a limit; the forecaster's own chance of this, stated with the estimate: 80%; the middle value lies beyond the limit too.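

In this assay compound 4 gives > 100000 nM, which is a limit of the assay and not a number. Ethoxy to methoxy on the 4-alkoxyphenyl group therefore gives no measurable gain in this series, though any change hidden beyond the limit stays out of sight, and the steps to compound 4 from compound 3 and from compound 1 cannot be read. Going by these compounds alone, the one readable step is an at least 12-fold higher number from compound 2 to compound 4 (1.09 log units; beyond the scatter), so compound 2 remains the only member with a number and the other three members rest on one shared limit: the limit of > 100000 nM in this assay, at which 3 of the 4 values shown sit.

The compounds shown leave open whether the number of compound 2 goes with the benzyl group or with its fluoro substituent, a question that a 4-methoxybenzyl or an unsubstituted benzyl group on the same nitrogen would address. They also leave open whether a hydroxy group, a longer chain such as propoxy, or a chain ending in an amine at the place of the ethoxy group would bring any 4-substituted phenyl amide off the limit.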